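The source may hold more compounds than are shown below. What is called first, only, known or untested is meant among the compounds shown, and "the series" means these compounds.

Working notes on the series. The shared core is shown by compound 1 `O=C(N/N=C/c1ccc(F)cc1)Nc1ccc(Oc2ccnc3[nH]ccc23)cc1`, which in a functional assay on MCF7 cells (Homo sapiens) for antiproliferative activity, read by MTT assay, with a stated time of 72 h (on this read-out lower numbers stand for stronger inhibition and higher numbers for weaker inhibition), gives 3720 nM. Among the measured compounds shown here, compound 2 `COc1ccc(/C=N/NC(=O)Nc2ccc(Oc3ccnc4[nH]ccc34)cc2)cc1` carries a 4-methoxyphenyl on the carbon with a double bond to nitrogen; in this assay compound 2 is recorded only as "not active" (no number reported), so no number fixes where it stands, and the pair compound 1 and compound 2 shows only that one gave a number and the other did not. Compound 3 `CN(C)CCCn1cccc1/C=N/NC(=O)Nc1ccc(Oc2ccnc3[nH]ccc23)cc1` has not been measured. The change from compound 2 to compound 3 is 1-(3-(dimethylamino)propyl)-1H-pyrrol-2-yl in place of 4-methoxyphenyl on a carbon with a double bond to nitrogen. With no number for compound 2 as the starting point, the size and direction of the step in this assay cannot be read from the shown data; an outcome near compound 1 or weaker is the plain expectation, with a real chance that again no number is reported. Compound 3 is expected to give about 6000 nM in this assay, estimated within 1000 nM to 40000 nM.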

Compound 3, half-maximal inhibitory concentration: 9140 nM
Estimate against measurement, compound 3: 1.5-fold (0.18 log units) below; measured number inside the range.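

In this assay, the place on the carbon with a double bond to nitrogen still gives a number when 1-(3-(dimethylamino)propyl)-1H-pyrrol-2-yl replaces 4-fluorophenyl, at a modest cost beyond the scatter (a 2.5-fold higher number from compound 1 to compound 3 (0.39 log units; beyond the scatter)). A six-membered aromatic ring of carbon only is therefore not required here for a measurable result, since a five-membered aromatic ring with 1 hetero atom also gives one. Compound 2 has no number, so steps from it cannot be read, and nothing shown bears on the cause of the step from compound 1.

The compounds shown do not separate the pyrrole ring from its chain, so plain 1H-pyrrol-2-yl remains open. Also open, going by these compounds, is how a morpholine or a carboxylic acid at the end of the propyl chain would compare with dimethylamino.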